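Swapping the Oxime for an Acetyl Group

The source may report more compounds than this note shows. Statements on the series, on what has been measured and on what is new or still open speak of the compounds shown alone.

Three compounds built on the same core were tested in a functional assay on the whole organism (strain albino) for inhibition, with Rattus norvegicus as the target, read by paw edema, with stated times of 30 min and 5 h, at a dose of 0.28 mmol/kg by the oral route; a higher number here means more inhibition at the dose given (going by the name of the read-out), a lower number less inhibition. Compound 1 `C=CCn1c(SCC(=O)Nc2ccc(C(C)=O)cc2)nnc1-c1ccccc1` carries a plain phenyl ring and an acetyl group and gives 63%. Compound 2 `CCn1c(SCC(=O)Nc2ccc(C(C)=O)cc2)nnc1-c1ccc(OC)cc1` bears a methoxyphenyl ring, an ethyl chain and the same acetyl group, and gives 62%. Compound 3 `C=CCn1c(SCC(=O)Nc2ccc(/C(C)=N/O)cc2)nnc1-c1ccc(OC)cc1` combines the methoxyphenyl ring and the allyl chain with an oxime in place of the acetyl, and gives 72%. The gaps from compound 3 to compound 1 and to compound 2 both fall within the usual scatter of repeated measurements, so the three numbers cannot be told apart.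

Compound 4 `C=CCn1c(SCC(=O)Nc2ccc(C(C)=O)cc2)nnc1-c1ccc(OC)cc1` has not been measured. It differs from compound 3 in one place: a group of 3 heavy atoms (2 carbon, 1 oxygen; no ring) in place of a group of 4 heavy atoms (2 carbon, 1 nitrogen, 1 oxygen; no ring), on an aromatic carbon — an acetyl enters, on an aromatic carbon of a six-membered aromatic ring of carbon only. Compound 1 and compound 2 already carry that acetyl and sit close to compound 3, so no step beyond the scatter is expected in this assay. For compound 4 an inhibition of 64% is expected, with a range from 52% to 76%. The expected step of a number 8 percentage points lower from compound 3 to compound 4 (within the scatter) stays within the scatter.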

Compound 4, a percentage reported as inhibition, in the whole organism at one dose (the size of the read-out at that dose, not a potency): 66%
Beside the measured number, compound 4's estimate is 2 percentage points below it; measured number inside the range.
By their numbers in this assay, from the lowest: compounds 2, 1, 4 and 3 (each within the scatter of the next).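

Among these compounds, compound 4 gives the first comparisons in which only one place differs, and in this assay replacing the oxime-bearing group with acetyl on the aromatic carbon, para to a large group, gives a number 6 percentage points lower from compound 3 to compound 4 (within the scatter). At this position, then, the oxime-bearing group and the acetyl cannot be told apart in this read-out, even though the group that leaves carries one hydrogen-bond donor and the acetyl carries none. The two other single changes read the same way, with vinyl in place of methyl on a saturated chain carbon bound to an aromatic nitrogen giving a number 4 percentage points higher from compound 2 to compound 4 (within the scatter) and methoxy in place of hydrogen on an aromatic carbon giving a number 3 percentage points higher from compound 1 to compound 4 (within the scatter), while no measurement at hand offers an explanation for any of these results.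

Still open, going by these compounds, is whether an amine or a carboxylic acid on that aromatic carbon, or a longer chain in place of the allyl, would give a step beyond the scatter. Also open, on these data alone, is how the four compounds compare in potency, since each number here is the size of the read-out at a single dose.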